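Hydroxy to hydrogen on the saturated ring carbon

The source may report more compounds than this note shows. Statements on the series, on what has been measured and on what is new or still open speak of the compounds shown alone.

Compound 1 `Cc1cc2c(cc1C(=O)N=C(N)N)S(=O)(=O)CC2(C)O` gives 30 nM in an assay on cells for inhibition of sodium/hydrogen exchanger (Oryctolagus cuniculus); a lower number here means a stronger inhibitor, a higher number a weaker inhibitor. Compound 3 `Cc1cc2c(cc1C(=O)N=C(N)N)S(=O)(=O)CC2C`, which carries hydrogen in place of hydroxy on a saturated ring carbon, gives 44 nM in this assay; the step of a 1.5-fold higher number from compound 1 to compound 3 (0.17 log units; within the scatter) is small. Compound 2 `Cc1cc2c(cc1C(=O)N=C(N)N)S(=O)(=O)C(C)(C)C2(C)O` gives 17 nM in this assay; how its core differs from that of compound 1 is not broken down here. The gap from compound 2 to compound 3 lies beyond the scatter, whereas that from compound 2 to compound 1 does not.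

Compound 4 `Cc1cc2c(cc1C(=O)N=C(N)N)S(=O)(=O)C(C)(C)C2C` has not yet been measured. It differs from compound 2 by hydrogen in place of hydroxy on a saturated ring carbon; this is the same kind of change as that from compound 1 to compound 3, though here the place is next to the ring atom that bears two methyl groups. On the strength of that single earlier step, the change is expected to give a 1.5-fold higher number from compound 2 to compound 4 (0.17 log units; within the scatter) in this assay, a step within the usual scatter. Compound 4 is therefore estimated at 25 nM in this assay, with a range of 12 nM to 55 nM.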

Compound 4, half-maximal inhibitory concentration: 14 nM
Beside the measured number, compound 4's estimate is 1.8-fold (0.25 log units) above it; measured number inside the range.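

In this assay hydrogen in place of hydroxy gives a 1.2-fold lower number from compound 2 to compound 4 (0.08 log units; within the scatter) and so stays small on this core, just as a 1.5-fold higher number from compound 1 to compound 3 (0.17 log units; within the scatter) did on the core first examined. Read together, the two steps do not separate, so within these two pairs the change carries from one core to the other: the same change on two cores in this assay, a 1.5-fold higher number (0.17 log units; within the scatter) from compound 1 to compound 3 and a 1.2-fold lower number (0.08 log units; within the scatter) from compound 2 to compound 4, 1.8-fold (0.25 log units) apart, within the scatter of two such steps

Two pairs are a thin base: they show that hydroxy can give way to hydrogen at this place on these two cores without a step beyond the scatter, but they fix no direction for the change and do not show that it would stay small on any further core.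

The compounds shown leave open whether another group on this saturated ring carbon, such as an amine, a methoxy group or a fluorine atom, would read like hydroxy or like hydrogen. They also leave open whether a longer chain, such as ethyl, in place of the methyl group on that carbon would leave the number unchanged.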